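A few compounds are considered here, and "the series" means these few. Any claim that something is new, unique, unknown or untested is made for them only; others in the source may bear on it.

Measured so far:
Compound 1, `CCCCCCCCNC(=O)[C@@H](NC(=O)c1ccccc1)[C@@H](C)O`, gives 111000 nM in a functional assay on MCF7 cells (Homo sapiens) for cytotoxicity, read by MTT assay, with a stated time of 48 h; on this read-out higher numbers stand for weaker inhibition and lower numbers for stronger inhibition.
Compound 2, `CCCCCCCCNC(=O)[C@@H](NC(=O)c1ccco1)[C@@H](C)O`, gives 91800 nM.
Compound 3, `CCCCCCCCCCCCCCCCCCNC(=O)[C@@H](NC(=O)c1ccccc1)[C@@H](C)O`, gives 31800 nM.

Compound 4, `CCCCCCCCCCCCCCCCCCNC(=O)[C@@H](NC(=O)c1ccco1)[C@@H](C)O`, has not yet been measured in this assay. It differs from compound 3 in one place: furan-2-yl in place of phenyl on a carbonyl carbon. The same change has already been made once among the measured compounds, from compound 1 to compound 2: furan-2-yl in place of phenyl on a carbonyl carbon. There it gave a 1.2-fold lower number from compound 1 to compound 2 (0.08 log units; within the scatter), a step that lies within the usual scatter of repeated measurements, so on that pair the change made no clear difference.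

The two cores on which this change is made are not the same. Compound 3 differs from compound 1 as follows: decyl in place of hydrogen on a saturated chain carbon, eight bonds along the chain from an amide-type nitrogen. That difference brought a 3.5-fold lower number from compound 1 to compound 3 (0.54 log units; beyond the scatter), and compound 3 gives the lowest number of the three measured compounds. The place of the change is described in the same words on both cores, so it is the same change on a different core.

Going by the values given here, the expectation for compound 4 rests on the single earlier pair: the step from compound 1 to compound 2 was a 1.2-fold lower number from compound 1 to compound 2 (0.08 log units; within the scatter), and a step of about the same size, a 1.2-fold lower number from compound 3 to compound 4 (0.07 log units; within the scatter), is expected from compound 3 to compound 4. Compound 4 is therefore estimated at 27000 nM, most likely somewhere between 12000 nM and 60000 nM.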

Compound 4, half-maximal inhibitory concentration: 21400 nM
Compound 4: the middle estimate sits 1.3-fold (0.10 log units) above what was measured, and the stated range covers the measured number.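

In this assay, putting furan-2-yl in place of phenyl on the long-chain core gave a 1.5-fold lower number from compound 3 to compound 4 (0.17 log units; within the scatter), so once again the swap made no clear difference, and the two steps agree: the same change on two cores in this assay, a 1.2-fold lower number (0.08 log units; within the scatter) from compound 1 to compound 2 and a 1.5-fold lower number (0.17 log units; within the scatter) from compound 3 to compound 4, 1.2-fold (0.09 log units) apart, within the scatter of two such steps. The chain difference also carried over, giving a 4.3-fold lower number from compound 2 to compound 4 (0.63 log units; beyond the scatter) among the furan-2-yl compounds, much as it did among the phenyl compounds: the same change on two cores in this assay, a 3.5-fold lower number (0.54 log units; beyond the scatter) from compound 1 to compound 3 and a 4.3-fold lower number (0.63 log units; beyond the scatter) from compound 2 to compound 4, 1.2-fold (0.09 log units) apart, within the scatter of two such steps. Within these four compounds, each change therefore had about the same effect on either core, but this rests on just two pairs per change and does not show that the same would hold for other groups or other cores.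

Still open, from the compounds shown here alone, is how a thiophen-2-yl or pyridinyl ring on the same carbonyl carbon would compare with phenyl and furan-2-yl, since these rings might not behave alike on both cores. Going by these compounds, it is also open whether a still longer chain, or one ending in an amine or a carboxylic acid, would give lower numbers.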